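Chloro position on the triazole aryl group, second core

The compounds below may be only part of what the source reports. "The series", "measured", "known", "first", "only" and "open" are said of these compounds alone.

Compound 1 `O=c1[nH]cc(S(=O)(=O)Nc2ccccc2-c2cn(-c3cccc(Cl)c3)nn2)c(=O)[nH]1` and compound 2 `O=c1[nH]cc(S(=O)(=O)Nc2ccccc2-c2cn(-c3ccc(Cl)cc3)nn2)c(=O)[nH]1` share one core; compound 3 `O=c1[nH]cc(S(=O)(=O)Nc2ccc(-c3cn(-c4cccc(Cl)c4)nn3)cc2)c(=O)[nH]1` and compound 4 `O=c1[nH]cc(S(=O)(=O)Nc2ccc(-c3cn(-c4ccc(Cl)cc4)nn3)cc2)c(=O)[nH]1` share another. The difference between the two cores is not broken down here. In a functional assay on OVCAR-3 cells (Homo sapiens) for antiproliferative activity, read by MTT assay, with a stated time of 24 h (a higher number here means a weaker inhibitor, a lower number a stronger inhibitor), compound 1 gives 2180 nM, compound 2 gives 1750 nM and compound 3 gives 2750 nM. The change from compound 1 to compound 2 is 4-chlorophenyl in place of 3-chlorophenyl on an aromatic nitrogen and made a step of a 1.2-fold lower number from compound 1 to compound 2 (0.10 log units; within the scatter). The change from compound 3 to compound 4 is 4-chlorophenyl in place of 3-chlorophenyl on an aromatic nitrogen, the same kind of change at the same kind of place. Since the earlier step stayed within the scatter, the step from compound 3 to compound 4 is expected to be small as well, about a 1.2-fold lower number from compound 3 to compound 4 (0.08 log units; within the scatter). Compound 4 is therefore estimated at 2300 nM, with a range from 1200 nM to 4500 nM.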

Compound 4, half-maximal inhibitory concentration: 2160 nM
For compound 4 the middle estimate is 1.1-fold (0.03 log units) above the measured one; low and high end bracket the measured number.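

In this assay, 4-chlorophenyl in place of 3-chlorophenyl on the aromatic nitrogen gives a step of a 1.3-fold lower number from compound 3 to compound 4 (0.10 log units; within the scatter). The same change on the two cores gives matching steps: the same change on two cores in this assay, a 1.2-fold lower number (0.10 log units; within the scatter) from compound 1 to compound 2 and a 1.3-fold lower number (0.10 log units; within the scatter) from compound 3 to compound 4, 1.0-fold (0.01 log units) apart, within the scatter of two such steps. This shows that the change stayed within the scatter on both cores in this one assay, but both steps are too small to show any real effect of the chloro position or to show how a larger step would carry from one core to the other.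

Open, going by these compounds, is whether this agreement between the cores holds when the chlorine on the aryl group gives way to another group, such as methoxy, an amine or a carboxylic acid. Also open, on these data alone, is whether it holds in any other assay.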